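Fluoro to trifluoromethyl at the assay limit

The compounds below may be only part of what the source reports. "The series", "measured", "known", "first", "only" and "open" are said of these compounds alone.

Values in a functional assay on HUVEC cells (Homo sapiens) for antiproliferative activity, read by MTT assay, with a stated time of 24 h (on this read-out higher numbers stand for weaker inhibition and lower numbers for stronger inhibition), follow. Each one is a limit of the assay and not a number.

- compound 1 `C=CC(C)(C)c1cc(-c2ccc(OC)cc2)ccc1O` | > 100000 nM
- compound 2 `C=CCc1cc(-c2ccc(F)cc2)ccc1O` | > 100000 nM
- compound 3 `C=CCc1ccc(OCC)c(-c2ccc(OCC)c(CC=C)c2)c1` | > 100000 nM

Compound 2 gives > 100000 nM as a limit, with no number behind it. Going by the values given here, the same holds across the set (the limit of > 100000 nM in this assay, at which 3 of the 3 values shown sit), so the series offers no measured value to rank and no measured step to scale from.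

Compound 4 `C=CCc1cc(-c2ccc(C(F)(F)F)cc2)ccc1O` differs from compound 2 by one change. Trifluoromethyl stands in place of fluoro on an aromatic carbon of a six-membered aromatic ring of carbon only, para to a large group (trifluoromethyl in place of fluoro on an aromatic carbon).

Among the compounds with values here, with no measured step to go on, no step beyond the scatter is expected in this assay for this change. A measurable number remains possible, and it could only show stronger inhibition than the limit of compound 2 allows. The expected step is a number no higher from compound 2 to compound 4 (the limit leaves the size open) and it remains an estimate. The most likely report for compound 4 is again a limit. For compound 4 the estimated value is 100000 nM with an expected range from 40000 nM to 200000 nM in this assay when a number is reported.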

Compound 4, half-maximal inhibitory concentration: 74000 nM
Compound 4: the middle estimate sits 1.4-fold (0.13 log units) above what was measured; the range from low to high includes it.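

In this assay, compound 4 is the only compound shown that returns a number, 74000 nM, so the position on the aromatic carbon para to a large group is one where a substituent change can be followed by a readable value. Trifluoromethyl in place of fluoro there gives an at least 1.3-fold lower number from compound 2 to compound 4 (0.13 log units; that floor lies within the scatter), and this is a floor rather than a measured size, so the change may be small or may be larger, and the data do not separate the two. Compound 4 is also the only value in the set that lies clear of the limit, which makes it the sole numerical anchor for the series: the limit of > 100000 nM in this assay, at which 3 of the 4 values shown sit.

On these data alone, the true size of the step remains open, as compound 2 has only a limit and no number to scale from. Also open, as far as these compounds go, is how other groups on the same aromatic carbon would read in this assay, for example a nitrile, an amine, a carboxylic acid or a longer chain such as pentafluoroethyl, and whether any of them would give a number well below that of compound 4.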